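A few compounds are considered here, and "the series" means these few. Any claim that something is new, unique, unknown or untested is made for them only; others in the source may bear on it.

In a functional assay on NCI-H460 cells (Homo sapiens) for cytotoxicity, read by sulforhodamine B assay, with a stated time of 3 days; on this read-out lower numbers stand for stronger inhibition and higher numbers for weaker inhibition:
- compound 1 `CC(C)Cn1cc(C=O)c2ccccc21`: 1990 nM
- compound 2 `OCc1cn(Cc2ccc(Cl)cc2)c2ccccc12`: 16 nM
- compound 3 `OCCc1cn(Cc2ccc(Cl)cc2)c2ccccc12`: > 31600 nM

For compound 3 only a limit is known, > 31600 nM, and not a number.

Compound 4 `CC(O)c1cn(Cc2ccc(Cl)cc2)c2ccccc12` carries 1-hydroxyethyl in place of 2-hydroxyethyl on an aromatic carbon.

Among the compounds with values here, one measured step bears on this change, an at least 1900-fold higher number from compound 2 to compound 3 (3.29 log units; beyond the scatter). That step, large and beyond the scatter, altered the same hydroxy-bearing chain, and the new change shifts the hydroxy back along it. A large fall in the number is therefore expected, though perhaps not a full return. The expected change is an at least 150-fold lower number from compound 3 to compound 4 (2.19 log units; beyond the scatter). For compound 4 the estimated value is 200 nM, with an expected range of 20 nM to 3000 nM.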

Compound 4, half-maximal inhibitory concentration: 25100 nM
The estimate for compound 4 lay 130-fold (2.10 log units) below the measured number; measured number outside the range, above it.
By their numbers in this assay, from the lowest: compound 2; then compound 1; then compound 4. At a limit, above all of these: compound 3.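

In this assay a methyl added to the hydroxy-bearing chain carbon of compound 2 gives a large step (a 1600-fold higher number from compound 2 to compound 4 (3.20 log units; beyond the scatter)). So the low number of compound 2 did not survive in 1-hydroxyethyl, which keeps the hydroxy on the carbon bound to the aromatic ring. The next step (an at least 1.2-fold lower number from compound 3 to compound 4 (0.10 log units; that floor lies within the scatter)) starts from a limit and its floor lies within the scatter, so its size cannot be read. Compound 3 has only a limit: the limit of > 31600 nM in this assay, at which 1 of the 4 values shown sits.

Going by these compounds, it remains open whether the hydroxy itself matters or only the small size of hydroxymethyl. An aminomethyl or methoxymethyl group on this aromatic carbon would help separate the two.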